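Sulfonyl change in a series at the assay limit

The compounds below may be only part of what the source reports. "The series", "measured", "known", "first", "only" and "open" are said of these compounds alone.

Measured in a functional assay on the whole organism for inhibition, with Rattus norvegicus as the target; on this read-out lower numbers stand for an effect already at smaller amounts and higher numbers for an effect only at larger amounts of compound:
- compound 1 `COc1ccc(S(=O)(=O)NC(=O)C(C)(Cc2ccc(Cl)cc2)Oc2ccc(C(C)C)cc2)cc1`: > 10 mg/kg, a limit
- compound 2 `CC(C)c1ccc(OC(C)(C(=O)NS(=O)(=O)C(F)(F)F)C(C)c2ccc(Cl)cc2)cc1`: > 10 mg/kg, a limit

Compound 2 stands at the limit of > 10 mg/kg in this assay, at which 2 of the 2 values shown sit, so it offers a limit and no number. Compound 3 `COc1ccc(S(=O)(=O)NC(=O)C(C)(Oc2ccc(C(C)C)cc2)C(C)c2ccc(Cl)cc2)cc1` differs from it by 4-methoxyphenyl in place of trifluoromethyl on a sulfonyl sulfur. Compound 1 also carries 4-methoxyphenyl and gives > 10 mg/kg, again only a limit. No step beyond the scatter, in either direction, is expected in this assay. The expected change is a step that the limit leaves unreadable from compound 2 to compound 3. For compound 3 the estimated value is 15 mg/kg, with an expected range of 5 mg/kg to 40 mg/kg.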

Compound 3, dose for half-maximal effect: > 10 mg/kg
Compound 3 gave a limit, no number (the forecaster's own chance of this, stated with the estimate: 75%); the middle value does not contradict the limit.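

Compound 3 gives > 10 mg/kg, a limit, so the steps to it from compound 1 and compound 2 cannot be read. The compounds shown leave open whether the sulfonyl change or the added methyl alters the half-maximal dose at all.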